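Swapping one amine on a shared chlorinated core

The compounds below may be only part of what the source reports. "The series", "measured", "known", "first", "only" and "open" are said of these compounds alone.

Compound 1 (`CC[C@H](C)Nc1nc(Cl)nc(N[C@@H](C)c2ccccc2)n1`) gives 14100 nM
Compound 2 (`CCCN(C)c1nc(Cl)nc(N[C@H](C)c2ccccc2)n1`) gives 9770 nM

Both values come from an ADME assay on the whole organism for inhibition, with Echinochloa crus-galli var. formosensis as the target, with a stated time of 4 days (a higher number here means a weaker inhibitor, a lower number a stronger inhibitor), and lie within the usual scatter of each other. Compound 2 therefore stands level with compound 1 on these two numbers.

The next compound is compound 3 (`CC[C@@H](C)Nc1nc(Cl)nc(N[C@H](C)c2ccccc2)n1`), in which (sec-butyl)amino replaces methyl(propyl)amino on an aromatic carbon ((sec-butyl)amino in place of methyl(propyl)amino on an aromatic carbon). Compound 3 is also the mirror image of compound 1, carrying the same groups with both stereocentres inverted. Among the compounds with values here, no measured pair isolates this swap, so the data give no size for it. Within the data shown here, compound 1, the only measured compound with a sec-butyl group, reads 14100 nM but its opposite handedness makes it a loose guide at best. A modest move toward a lower number in this assay is nevertheless expected, though with wide uncertainty. The expected step is a 2.4-fold lower number from compound 2 to compound 3 (0.39 log units; beyond the scatter) as an estimate only. For compound 3 the estimated value is 4000 nM with an expected range from 800 nM to 15000 nM in this test.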

Compound 3, half-maximal inhibitory concentration: 4570 nM
Compound 3: the middle estimate sits 1.1-fold (0.06 log units) below what was measured, within the range that was stated.
By their numbers in this assay, from the lowest: compound 3; then compounds 2 and 1 (each within the scatter of the next).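

The change at this position, on an aromatic carbon between two ring nitrogen atoms, now has a measured size: in this assay, putting (sec-butyl)amino in place of methyl(propyl)amino gives a 2.1-fold lower number from compound 2 to compound 3 (0.33 log units; beyond the scatter). The two groups have the same atoms, joined differently, and the entering group has 1 hydrogen-bond donor where the leaving group has 0, but this single pair cannot tell how much either feature contributes, or whether the step would keep its size with a different configuration elsewhere in the molecule. Handedness also proves to matter, since compound 3 is the strongest inhibitor of the three, and the gap of a 3.1-fold lower number from compound 1 to compound 3 (0.49 log units; beyond the scatter) can be put down to stereochemistry alone because nothing else separates the pair: the fact that compounds 1 and 3 differ only in the configuration as drawn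

Since both stereocentres are inverted together, the compounds shown leave open whether one of them or both together account for that step. They also leave open how this assay would respond to a cyclopropylamino group or a longer chain such as pentylamino at the same position, or to a methoxy group in place of the chloro group.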